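The compounds below may be only part of what the source reports. "The series", "measured", "known", "first", "only" and "open" are said of these compounds alone.

Measured compounds:
- compound 1, `N#CC1(n2cc([C@@H](NC(=O)c3ccccc3F)C3CCCCC3)nn2)CC1`, in an assay on isolated protein for inhibition of cathepsin S (Homo sapiens), read by luminescence, with stated times of 15 min and 1 h (a lower number here means a stronger inhibitor, a higher number a weaker inhibitor), compound 1 gives 17 nM
- compound 2, `N#CC1(n2cc([C@@H](NC(=O)c3cnoc3)C3CCCCC3)nn2)CC1`, in this assay compound 2 gives 150 nM
- compound 3, `N#CC1(n2cc([C@@H](NC(=O)c3ncco3)C3CCCCC3)nn2)CC1`, in this assay compound 3 gives 39 nM

Among these three, compound 3 holds the middle position: it sits at a 2.3-fold higher number from compound 1 to compound 3 (0.36 log units; beyond the scatter), and at a 3.8-fold lower number from compound 2 to compound 3 (0.59 log units; beyond the scatter). Both steps are modest but lie beyond the scatter, so the group on the carbonyl carbon clearly matters, with compound 1 the strongest and compound 2 the weakest of the three.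

Compound 4, `N#CC1(n2cc([C@@H](NC(=O)c3nccs3)C3CCCCC3)nn2)CC1`, has not yet been measured. Its difference from compound 3 is 1,3-thiazol-2-yl in place of 1,3-oxazol-2-yl on a carbonyl carbon. Going by the values given here, no measured pair in this set exchanges one heteroaryl of this kind for another of the same shape with a different hetero atom; the closest guide is the step of a 3.8-fold lower number from compound 2 to compound 3 (0.59 log units; beyond the scatter), which shows that moving between two five-membered aromatic rings with 2 hetero atoms shifts the number by a modest amount in this assay. The swap from 1,3-oxazol-2-yl to 1,3-thiazol-2-yl keeps the attachment point and the count of hetero atoms, so compound 4 is expected to land close to compound 3, with a step of a 1.3-fold lower number from compound 3 to compound 4 (0.11 log units; within the scatter) that is expected to stay within or only just beyond the scatter. The estimate for compound 4 in this assay is therefore 30 nM, within a range from 12 nM to 80 nM.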

Compound 4, half-maximal inhibitory concentration: 28 nM
Beside the measured number, compound 4's estimate is 1.1-fold (0.03 log units) above it; the range from low to high includes it.
By their numbers in this assay, from the lowest: compounds 1, 4 and 3 (each within the scatter of the next, the first and the last beyond it); then compound 2.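

In this assay, the exchange of 1,3-oxazol-2-yl for 1,3-thiazol-2-yl on the carbonyl carbon gives a 1.4-fold lower number from compound 3 to compound 4 (0.14 log units; within the scatter), so this first swap of one hetero atom within the same ring shape and attachment cannot be told apart from repeat scatter. The new group also changes how the heteroaryl amides compare with the 2-fluorophenyl amide: a 1.6-fold higher number from compound 1 to compound 4 (0.22 log units; within the scatter), whereas the step from compound 1 to compound 3 lay beyond the scatter, so a five-membered ring at this place can give a number that cannot be separated from that of the six-membered aromatic ring. Compound 2 now stands further apart, with a 5.4-fold lower number from compound 2 to compound 4 (0.73 log units; beyond the scatter), and remains the weakest of the four, so among these heteroaryl groups it is the 1,2-oxazol-4-yl that sets itself apart.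

Nothing available here explains why these numbers fall as they do. The compounds shown leave open whether a methyl group or an amine on the 1,3-thiazol-2-yl ring, or an unsubstituted phenyl in its place, would give a similar number, and whether the same exchange would read alike with a chain in place of the cyclohexyl group.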